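Carboxy to methylcarbamoyl on the shared core: kinetic solubility

The source may report more compounds than this note shows. Statements on the series, on what has been measured and on what is new or still open speak of the compounds shown alone.

Within the data shown here, compound 2 `COc1ccc(-c2cc(-c3ccc(C(=O)O)cc3)cnc2N)cn1` is the only member of the pair with a number in a physicochemical assay for solubility, read by nephelometry, measured as kinetic solubility, at pH 2; on this read-out higher numbers stand for higher solubility and lower numbers for lower solubility; in this assay compound 2 gives 12.5 ug/mL. Compound 1 `COc1ccc(-c2cc(-c3ccc(-n4cccn4)cc3)cnc2N)cn1` reaches only a limit of the assay, > 100 ug/mL, the limit named in the limit of > 100 ug/mL in this assay, at which 1 of the 2 values shown sits. Among the measured compounds shown here, the single measured step, an at least 8.0-fold lower number from compound 1 to compound 2 (0.90 log units; beyond the scatter), swaps 1H-pyrazol-1-yl for carboxy on an aromatic carbon.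

Compound 3 `CNC(=O)c1ccc(-c2cnc(N)c(-c3ccc(OC)nc3)c2)cc1` differs from compound 2 by methylamino in place of hydroxy on a carbonyl carbon, read one bond further out as carboxy to methylcarbamoyl. The measured step bears on this change only loosely: it touches the same position but exchanges the whole group, not merely the substituent on the carbonyl carbon, so it gives no direction for the present change. Its size, at least modest, does show that changes at this position can move the read-out beyond the scatter. For the measured compounds named here, no measured step compares methylcarbamoyl with carboxy. The expectation for compound 3 is therefore a step of a 1.6-fold higher number from compound 2 to compound 3 (0.20 log units; within the scatter), within the scatter, with wide uncertainty. Compound 3 is estimated at 20 ug/mL, with a range from 6 ug/mL to 70 ug/mL.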

Compound 3, solubility: 50 ug/mL
For compound 3 the middle estimate is 2.5-fold (0.40 log units) below the measured one; measured number inside the range.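

In this assay, the change on the carbonyl carbon now has a measured direction: a 4.0-fold higher number from compound 2 to compound 3 (0.60 log units; beyond the scatter). This position therefore responds not only to the exchange of a whole group but also to methylamino in place of hydroxy, with the carbonyl and the rest of the shared core unchanged. The comparison with 1H-pyrazol-1-yl is looser, reading an at least 2.0-fold lower number from compound 1 to compound 3 (0.30 log units; that floor lies within the scatter), so methylcarbamoyl and 1H-pyrazol-1-yl cannot be placed in order beyond the scatter, and the read-out for compound 1 is a limit and not a number: the limit of > 100 ug/mL in this assay, at which 1 of the 3 values shown sits.

As far as these compounds go, how the read-out runs with an unsubstituted amino group, dimethylamino or a longer chain such as ethylamino on the same carbonyl carbon remains open, so the step from hydroxy to methylamino cannot yet be extended into a trend. From the compounds shown here alone, the true size of the gap between 1H-pyrazol-1-yl and methylcarbamoyl also remains open, as does whether the step on the carbonyl carbon would hold on a different core.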